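The compounds below may be only part of what the source reports. "The series", "measured", "known", "first", "only" and "open" are said of these compounds alone.

The measured compounds:
compound 1, `CCC(=O)Nc1cccc(S(=O)(=O)Oc2ccccc2C(C)C)c1`, 12000 nM;
compound 2, `CCCC(=O)Nc1cccc(S(=O)(=O)Oc2ccccc2C(C)C)c1`, 15000 nM;
compound 3, `CCNC(=O)Nc1ccc(S(=O)(=O)Oc2ccccc2C(C)C)cc1`, 250 nM.

All three were tested in a functional assay on HT-1080 cells (Homo sapiens) for antiproliferative activity, read by sulforhodamine B assay, with a stated time of 48 h; a lower number here means a stronger inhibitor, a higher number a weaker inhibitor. Compound 3 gives the lowest number of the three; compound 1 lies a long way from it, and compound 2 further still, both gaps beyond the scatter. How the core of compound 3 differs from the core of compound 1 is not broken down here. Within the first pair, the step from compound 1 to compound 2 rests on one change, (methyl in place of hydrogen on a saturated chain carbon, two bonds along the chain from a carbonyl carbon), and it moves the read-out by a 1.3-fold higher number from compound 1 to compound 2 (0.10 log units; within the scatter).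

Compound 4, `CCCNC(=O)Nc1ccc(S(=O)(=O)Oc2ccccc2C(C)C)cc1`, has not yet been measured in this assay. It differs from compound 3 by methyl in place of hydrogen on a saturated chain carbon, two bonds along the chain from an amide-type nitrogen. That is the same kind of change as in the earlier pair, though not the same: there the entering carbon sits two bonds along the chain from a carbonyl carbon, here two bonds along the chain from an amide-type nitrogen. Because the earlier step of a 1.3-fold higher number from compound 1 to compound 2 (0.10 log units; within the scatter) stayed within the scatter, a step of similar size is expected here, a 1.2-fold higher number from compound 3 to compound 4 (0.08 log units; within the scatter). Compound 4 is therefore estimated at 300 nM, most likely between 120 nM and 750 nM.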

Compound 4, half-maximal inhibitory concentration: 680 nM
Compound 4: middle estimate off by 2.3-fold (0.36 log units), on the low side; measured number inside the range.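

In this assay, the change from ethylamino to propylamino gives a 2.7-fold higher number from compound 3 to compound 4 (0.43 log units; beyond the scatter), a modest step, while the same added methyl on the other core gave a 1.3-fold higher number from compound 1 to compound 2 (0.10 log units; within the scatter). Although only the first of these steps lies beyond the scatter, the two cannot be told apart when set side by side: the same change on two cores in this assay, a 1.3-fold higher number (0.10 log units; within the scatter) from compound 1 to compound 2 and a 2.7-fold higher number (0.43 log units; beyond the scatter) from compound 3 to compound 4, 2.2-fold (0.34 log units) apart, within the scatter of two such steps. Within the data shown here, this shows that the change has not been seen to behave differently on the two cores, but it does not show that it carries over unchanged, as there is only one pair on each core and the gap between them is not small enough to settle the matter.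

The compounds shown leave open whether a longer chain, such as butylamino, would take the number higher still on the core of compound 3, and whether a branched isopropylamino group would match the straight chain. They also leave open how a chain ending in an amine or a carboxylic acid would read in this assay.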